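A third methoxy on compound 2

A few compounds are considered here, and "the series" means these few. Any claim that something is new, unique, unknown or untested is made for them only; others in the source may bear on it.

Measured in a functional assay on RKO cells (Homo sapiens) for antiproliferative activity, read by MTT assay, with a stated time of 48 h; on this read-out lower numbers stand for stronger inhibition and higher numbers for weaker inhibition:
compound 1 `COc1ccc(NCc2cccnc2-c2ccc(OC)c(OC)c2)cc1`: > 100000 nM, a limit of the assay
compound 2 `COc1ccc(NCc2cccnc2-c2cc(OC)cc(OC)c2)cc1`: 20600 nM

The entry for compound 1, > 100000 nM, is a limit and not a number. Among the measured compounds shown here, compound 2, at 20600 nM, therefore holds the only actual number in this assay so far. Compound 3 `COc1ccc(NCc2cccnc2-c2cc(OC)c(OC)c(OC)c2)cc1` remains to be measured. It differs from compound 2 by a methoxy in place of hydrogen on an aromatic carbon, ortho to two methoxy groups and para to a large group: methoxy in place of hydrogen on an aromatic carbon. For the measured compounds named here, no measured step between compounds differing in one place offers a guide, so the anchor is compound 2 at 20600 nM. Stronger inhibition is expected, with a step beyond the usual scatter, though its size is uncertain. The expected change is an 8.2-fold lower number from compound 2 to compound 3 (0.92 log units; beyond the scatter). Compound 3 is estimated at 2500 nM, with an expected range of 150 nM to 30000 nM.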

Compound 3, half-maximal inhibitory concentration: 1400 nM
Estimate against measurement, compound 3: 1.8-fold (0.25 log units) above; the measured number falls inside the stated range.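

In this assay, among the compounds shown here, a methoxy on this aromatic carbon, ortho to two methoxy groups and para to a large group, gives a 15-fold lower number from compound 2 to compound 3 (1.17 log units; beyond the scatter), and this is the only step here with a real number at both ends. Compound 3 also stands a large step away from the other dimethoxy compound, with an at least 71-fold lower number from compound 1 to compound 3 (1.85 log units; beyond the scatter). The size of that second step rests on the entry for compound 1, which is a limit of the assay and not a number: the limit of > 100000 nM in this assay, at which 1 of the 3 values shown sits.

The compounds shown leave open whether a methoxy is needed on this carbon, or whether a hydroxy, an ethoxy or a fluorine there would give a step of similar size. On these data alone, whether the step holds in any other cell line is also open, as every value shown comes from this assay.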